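Swapping Chloro for Bromo on the Chlorophenyl Group

The source may report more compounds than this note shows. Statements on the series, on what has been measured and on what is new or still open speak of the compounds shown alone.

Three compounds share one core and differ only in the chlorophenyl group that sits on an oxygen on an aromatic ring. Compound 1 `N[C@@H](COP(=O)(O)OCCCOC(=O)CCc1ccccc1OCc1cccc(Oc2ccccc2Cl)c1)C(=O)O` gives 19.8% in an assay on cells for agonist activity at probable G-protein coupled receptor 34 (Mus musculus), with a stated time of 1 h; a lower number here means a smaller maximal response, a higher number a larger maximal response. Compound 2 `N[C@@H](COP(=O)(O)OCCCOC(=O)CCc1ccccc1OCc1cccc(Oc2cccc(Cl)c2)c1)C(=O)O` gives 17.1% in this assay, and compound 3 `N[C@@H](COP(=O)(O)OCCCOC(=O)CCc1ccccc1OCc1cccc(Oc2ccc(Cl)cc2)c1)C(=O)O` gives 17.8% there. Among these three numbers compound 3 stands second highest, with compound 2 nearest and compound 1 furthest, both within the scatter. The steps of a number 2.7 percentage points lower from compound 1 to compound 2 (within the scatter), a number 2 percentage points lower from compound 1 to compound 3 (within the scatter) and a number 0.7 percentage points higher from compound 2 to compound 3 (within the scatter) all fall within the scatter, so changing which chlorophenyl group is present has not altered the maximal response as far as these measurements can tell.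

Compound 4 `N[C@@H](COP(=O)(O)OCCCOC(=O)CCc1ccccc1OCc1cccc(Oc2ccc(Br)cc2)c1)C(=O)O` has not yet been measured. It differs from compound 3 in one place: bromo in place of chloro on an aromatic carbon. Within the data shown here, no measured step exchanges one halogen for another, so the three steps bear on this change only loosely: they show that small changes to this group have left the response within the scatter each time. Compound 4 is therefore expected to show a step of a number 0.2 percentage points higher from compound 3 to compound 4 (within the scatter), meaning no change beyond the scatter. The estimated value for compound 4 is 18%, with a range from 10% to 26%.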

Compound 4, largest response reached (Emax), in percent of the reference or control that the assay uses: 17.7%
Beside the measured number, compound 4's estimate is 0.3 percentage points above it; the range from low to high includes it.
By their numbers in this assay, from the lowest: compounds 2, 4, 3 and 1 (each within the scatter of the next).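

Among these compounds, the exchange of 4-chlorophenyl for 4-bromophenyl is the first swap of one halogen for another at this position, and in this assay it gives a number 0.1 percentage points lower from compound 3 to compound 4 (within the scatter) so chloro and bromo on this aromatic carbon cannot be told apart by these measurements. The bromo compound also shows a number 0.6 percentage points higher from compound 2 to compound 4 (within the scatter) and a number 2.1 percentage points lower from compound 1 to compound 4 (within the scatter) so the comparison with chloro at the other ring positions reveals no difference beyond the scatter either, and the maximal response remains indistinguishable across all four compounds. Nothing available explains why this response is so insensitive to these changes.

From the compounds shown here alone, all four compounds carry a single halogen on this phenyl group, so it remains open whether a different kind of group there, such as an amine, a carboxylic acid or a methoxy group, would move the maximal response beyond the scatter. Going by these compounds, it is also open whether two halogens on this ring, or a longer chain elsewhere in the shared core, would leave the response just as unchanged.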